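The source may hold more compounds than are shown below. What is called first, only, known or untested is meant among the compounds shown, and "the series" means these compounds.

In an ADME assay on J774 cells (Mus musculus) for antiproliferative activity, with a stated time of 72 h (a higher number here means that more compound is needed for the effect, a lower number that less compound is needed), two compounds have been measured:
compound 1 `CCCCc1cc2c(=O)c(CC)c(C)[nH]c2cc1OCCOc1ccccc1` gives 1000 nM
compound 2 `CCc1c(C)[nH]c2cc(OCCOc3ccccc3)c(Br)cc2c1=O` gives > 25000 nM as a limit

For compound 2 the reading > 25000 nM is a limit of the assay and not a number. Compound 3 `CCc1c(C)[nH]c2cc(OCCOc3ccccc3)ccc2c1=O` has hydrogen in place of bromo on an aromatic carbon, and hydrogen in place of bromo on an aromatic carbon gives the full count. Going by the values given here, the one measured step at that carbon, bromo in place of butyl, is an at least 25-fold higher number from compound 1 to compound 2 (1.39 log units; beyond the scatter) and it is large. It says nothing directly about hydrogen. Compound 3 lacks the butyl of compound 1 at 1000 nM and is therefore expected to lie much nearer compound 2 in this assay. Compound 3 may again reach the limit of the assay. The expected size is an at least 1.6-fold lower number from compound 2 to compound 3 (0.22 log units; that floor lies within the scatter) and this remains an estimate. For compound 3 the estimated value is 15000 nM with an expected range from 4000 nM to 40000 nM for this estimate.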

Compound 3, half-maximal effective concentration: 4000 nM
Compound 3: middle estimate off by 3.8-fold (0.57 log units), on the high side; measured number inside the range.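

In this assay hydrogen in place of bromo on the aromatic carbon gives an at least 6.2-fold lower number from compound 2 to compound 3 (0.79 log units; beyond the scatter) and thus shows that bromo raises the number relative to the unsubstituted carbon. Hydrogen in place of butyl gives a 4.0-fold higher number from compound 1 to compound 3 (0.60 log units; beyond the scatter) and so puts hydrogen between the two substituents, with butyl needing the least compound of the three and bromo the most. Compound 2 reads as a limit and not a number, so its step to compound 3 gives only a floor for the size of the bromo change: the limit of > 25000 nM in this assay, at which 1 of the 3 values shown sits.

The compounds shown leave open whether a propyl group or a chain longer than butyl at this carbon would lower the number further. They also leave open on which side of hydrogen a methyl, a methoxy, a chlorine or an amine would fall.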